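The source may report more compounds than this note shows. Statements on the series, on what has been measured and on what is new or still open speak of the compounds shown alone.

Measured compounds:
Compound 1 `Oc1ccc(-c2cc(-c3ccco3)cc(-c3ccc(O)cc3)n2)cc1` — > 50000 nM
Compound 2 `Oc1ccc(-c2cc(-c3cccnc3)cc(-c3cccc(O)c3)n2)cc1` — 6390 nM

In a functional assay on DU-145 cells (Homo sapiens) for cytotoxicity, read by CCK-8 assay (a lower number here means a stronger inhibitor, a higher number a weaker inhibitor), compound 1 gives only a limit, > 50000 nM, not a number. Compound 2 gives 6390 nM in this assay, and this is the only actual number shown. Among the measured compounds shown here, the one other value shown, that of compound 1, is a limit (the limit of > 50000 nM in this assay, at which 1 of the 2 values shown sits), so compound 2 cannot be placed above or below any measured partner.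

Compound 3 `Oc1ccc(-c2cc(-c3cccnc3)cc(-c3ccc(O)cc3)n2)cc1` has not yet been measured in this assay. Its difference from compound 2 is 4-hydroxyphenyl in place of 3-hydroxyphenyl on an aromatic carbon, so that both aryl groups on the six-membered aromatic ring with one nitrogen now carry the hydroxyl in the same position. For the measured compounds named here, no measured pair differing only in this way is available, so the size of the step rests on judgment alone. Moving a hydroxyl between two positions on an otherwise unchanged ring most often shifts potency modestly, and the step from compound 2 to compound 3 is expected to be a 1.4-fold higher number from compound 2 to compound 3 (0.15 log units; within the scatter), toward the weaker side but not clearly beyond the usual scatter. Compound 3 is therefore estimated at 9000 nM in this assay, within a range from 2500 nM to 35000 nM.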

Compound 3, half-maximal inhibitory concentration: 240 nM
Compound 3: the middle estimate sits 38-fold (1.57 log units) above what was measured; measured number below the stated range.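

Compound 2 and compound 3 hold the same atoms, so this pair isolates the place of one hydroxyl on the aryl group next to the ring nitrogen. In this assay, changing 3-hydroxyphenyl to 4-hydroxyphenyl gives a 27-fold lower number from compound 2 to compound 3 (1.43 log units; beyond the scatter), which shows that this one place responds strongly to a change that adds and removes no atoms, something the earlier two compounds could not show. With 4-hydroxyphenyl held on both sides, a second place also proves to matter, as pyridin-3-yl in place of furan-2-yl gives an at least 200-fold lower number from compound 1 to compound 3 (2.31 log units; beyond the scatter), although that step has a limit at one end, not a number, as compound 1 gives only a limit: the limit of > 50000 nM in this assay, at which 1 of the 3 values shown sits.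

The compounds shown do not tell whether the hydroxyl itself is needed, or whether a methoxy group or an amine in its stead on the same ring would keep the low number of compound 3. They also leave open whether the gain from moving the hydroxyl would hold with furan-2-yl in the place of pyridin-3-yl, and they give no explanation for the size of either step.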